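The source may hold more compounds than are shown below. What is called first, only, known or untested is meant among the compounds shown, and "the series" means these compounds.

Three aryl selenium compounds have been measured so far in a functional assay on CCRF-CEM cells (Homo sapiens) for cytotoxicity, read by MTT assay, with a stated time of 72 h; on this read-out lower numbers stand for stronger inhibition of growth and higher numbers for weaker inhibition of growth. Compound 1 `O=C(Nc1ccc([Se][Se]c2ccc(NC(=O)OCc3ccccc3)cc2)cc1)OCc1ccccc1` gives 34600 nM. Compound 2 `CCCCCCOC(=O)Nc1ccc([Se]C#N)cc1` gives 46200 nM in this assay. Compound 3 `N#C[Se]c1ccc(NC(=O)Oc2ccc(F)cc2)cc1`, which carries a fluorophenyl carbamate, gives 41900 nM in this assay; its number lies within the usual scatter of both compound 1 and compound 2, so the three results cannot be told apart.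

Compound 4 `N#C[Se]c1ccc(NC(=O)Oc2ccc(Cl)cc2)cc1` has not yet been measured. It differs from compound 3 in one place only: chloro in place of fluoro on an aromatic carbon. Among the measured compounds there is no pair that differs in a single place, so no step of known size can guide the expectation, and the change of one halogen for another at this place has no precedent here.

Compound 4 is therefore expected to give a number close to that of compound 3, with the step from a 1.1-fold lower number from compound 3 to compound 4 (0.04 log units; within the scatter) estimated to stay within the scatter, in no sure direction. Compound 4 is estimated at 38000 nM in this assay, within a range from 19000 nM to 76000 nM.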

Compound 4, concentration for total growth inhibition: 45100 nM
The estimate for compound 4 lay 1.2-fold (0.07 log units) below the measured number; the measured number falls inside the stated range.
By their numbers in this assay, from the lowest: compounds 1, 3, 4 and 2 (each within the scatter of the next).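

In this assay, going by these compounds alone, the exchange of fluoro for chloro on an aromatic carbon, para to a large group, gives the first step that can be read at a single place: a 1.1-fold higher number from compound 3 to compound 4 (0.03 log units; within the scatter). At this place on the ring, therefore, the two halogens cannot be told apart, and the change of one for the other leaves no readable mark on growth inhibition in these cells. No measurement shown here offers an explanation for this result.

From the compounds shown here alone, whether a different kind of group at the same place, such as an amine, a carboxylic acid or a longer chain, would give a step beyond the scatter remains open. Also open is what replacing the nitrile on selenium with a methyl would do, as no pair shown isolates that change.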